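The source may report more compounds than this note shows. Statements on the series, on what has been measured and on what is new or still open speak of the compounds shown alone.

Among the measured compounds shown here, compound 1, with the structure `NC(=O)c1c(NC(=O)c2ccccc2Cl)sc2c1CCN(Cc1ccc(Cl)cc1)C2`, is the only compound of this small set that gives a number in a functional assay on HL-60 cells (Homo sapiens) for antiproliferative activity, with a stated time of 24 h; a lower number here means a stronger inhibitor, a higher number a weaker inhibitor. In this assay compound 1 gives 22500 nM. Its partner compound 2, with the structure `NC(=O)c1c(NC(=O)c2ccc(C(F)(F)F)cc2)sc2c1CCN(Cc1ccc(Cl)cc1)C2`, is measured in the same way, and in this assay compound 2 gives > 50000 nM, which is a limit of the assay and not a number. The step from one to the other, an at least 2.2-fold higher number from compound 1 to compound 2 (0.34 log units; beyond the scatter), reflects a change on the carbonyl carbon. The supporting detail is the limit of > 50000 nM in this assay, at which 1 of the 2 values shown sits.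

Compound 3, with the structure `NC(=O)c1c(NC(=O)c2ccccc2Cl)sc2c1CCN(C(=S)Nc1ccccc1F)C2`, differs from compound 1 at another position. The change is a group of 10 heavy atoms (7 carbon, 1 nitrogen, 1 fluorine, 1 sulfur; one six-membered aromatic ring of carbon only) in place of a group of 8 heavy atoms (7 carbon, 1 chlorine; one six-membered aromatic ring of carbon only), on an amine nitrogen in a ring. For the measured compounds named here, the one measured step concerns the carbonyl carbon, not the amine nitrogen in the ring, so no measured step bears directly on this change, and compound 1 already sits at a weak level in this assay. For compound 3 the expected result in this assay is 25000 nM, within 8000 nM to 80000 nM. The expected step is a 1.1-fold higher number from compound 1 to compound 3 (0.05 log units; within the scatter), which is judged to lie within the scatter.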

Compound 3, half-maximal inhibitory concentration: 4970 nM
For compound 3 the middle estimate is 5.0-fold (0.70 log units) above the measured one, and the stated range ends above it.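

In this assay, the amine nitrogen in the ring is a place where a change moves the result beyond the scatter: the group that replaces 4-chlorobenzyl gives a 4.5-fold lower number from compound 1 to compound 3 (0.66 log units; beyond the scatter). Among the compounds shown here, this is the first step in the set toward a stronger inhibitor, whereas the only earlier step, on the carbonyl carbon, runs the other way, with an at least 2.2-fold higher number from compound 1 to compound 2 (0.34 log units; beyond the scatter). Compound 2 carries a limit of the assay and not a number, so compound 1 and compound 3 are the only pair with two numbers to compare: the limit of > 50000 nM in this assay, at which 1 of the 3 values shown sits.

The entering group differs from 4-chlorobenzyl in several ways at once, bringing sulfur, nitrogen, fluorine, a double bond outside aromatic rings, a hydrogen-bond donor and a hydrogen-bond acceptor, so the compounds shown do not tell which of these goes with the lower number. From the compounds shown here alone, it also stays open whether a matching group with a carbonyl oxygen in place of the sulfur, or with a plain phenyl ring in place of the fluorinated one, would give a similar result, and whether the step would hold with 4-(trifluoromethyl)phenyl on the carbonyl carbon.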